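Allyl carbamate replacing isobutyl on a selenocyanate scaffold

The compounds below may be only part of what the source reports. "The series", "measured", "known", "first", "only" and "open" are said of these compounds alone.

Three carbamates sharing one core have been measured in an ADME assay on BEAS-2B cells (Homo sapiens) for cytotoxicity, read by MTT assay, with a stated time of 72 h; a higher number here means a weaker inhibitor of growth, a lower number a stronger inhibitor of growth. Compound 1 `CCCOC(=O)Nc1ccc([Se]C#N)cc1` gives 19200 nM, compound 2 `CCCCOC(=O)Nc1ccc([Se]C#N)cc1` gives 5000 nM, and compound 3 `CC(C)COC(=O)Nc1ccc([Se]C#N)cc1` gives 26900 nM, the highest number of the three. Its nearest neighbour is compound 1, since the step of a 1.4-fold higher number from compound 1 to compound 3 (0.15 log units; within the scatter) lies within the scatter, while the step of a 5.4-fold higher number from compound 2 to compound 3 (0.73 log units; beyond the scatter) is beyond it. The fourth member, compound 4 `C=CCOC(=O)Nc1ccc([Se]C#N)cc1`, differs from compound 3 by vinyl in place of isopropyl on a saturated chain carbon bound to an oxygen next to a carbonyl group. Within the data shown here, the steps that bear on this change are a 5.4-fold higher number from compound 2 to compound 3 (0.73 log units; beyond the scatter) and a 3.8-fold lower number from compound 1 to compound 2 (0.58 log units; beyond the scatter), both of which concern the size of the chain on the carbamate oxygen; the allyl chain of compound 4 matches the propyl chain of compound 1 in length, and compound 1 sits within the scatter of compound 3. In this assay, compound 4 is therefore expected to give 16000 nM, within a range from 6000 nM to 40000 nM. The step of a 1.7-fold lower number from compound 3 to compound 4 (0.23 log units; within the scatter) is expected to stay within the scatter.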

Compound 4, concentration for 50% growth inhibition: 21400 nM
Compound 4: middle estimate off by 1.3-fold (0.13 log units), on the low side, and the stated range covers the measured number.
By their numbers in this assay, from the lowest: compound 2; then compounds 1, 4 and 3 (each within the scatter of the next).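

In this assay, vinyl on the saturated chain carbon bound to an oxygen next to a carbonyl group cannot be told apart from isopropyl or ethyl there: a 1.3-fold lower number from compound 3 to compound 4 (0.10 log units; within the scatter) and a 1.1-fold higher number from compound 1 to compound 4 (0.05 log units; within the scatter) both lie within the scatter, so a double bond outside aromatic rings at this place separates compound 4 from neither of these two. Only a 4.3-fold higher number from compound 2 to compound 4 (0.63 log units; beyond the scatter) lies beyond the scatter, so the butyl chain of compound 2 now stands apart from an unsaturated chain as well as from the two saturated ones. Nothing measured here offers an explanation for this pattern.

Open, on these data alone, is whether the separation of compound 2 follows chain length alone: a pentyl chain, or a butenyl chain carrying the double bond at the length of butyl, would bear on that. Also open, as far as these compounds go, is how a hydroxyl or an amine at the end of the chain would read in this assay.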